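The compounds below may be only part of what the source reports. "The series", "measured", "known", "first", "only" and "open" are said of these compounds alone.

Three compounds built on one shared core have been examined in a functional assay on MCF7 cells (Homo sapiens) for cytotoxicity, read by MTT assay, with a stated time of 4 days; on this read-out higher numbers stand for weaker inhibition and lower numbers for stronger inhibition. Compound 1, `C=C1C[C@]23C[C@@]1(O)CC[C@@H]2c1cccc(C)c1[C@@H]3Cn1cc(-c2ccc(OC)cc2)nn1`, carries a methoxy group on a phenyl ring; in this assay compound 1 gives > 20000 nM, which is a limit of the assay and not a number. Compound 2, `C=C1C[C@]23C[C@@]1(O)CC[C@@H]2c1cccc(C)c1[C@@H]3Cn1cc(-c2ccc(Cl)cc2)nn1`, has chloro in place of that methoxy; compound 2 gives > 20000 nM, again a limit. Compound 3, `C=C1C[C@]23C[C@@]1(O)CC[C@@H]2c1cccc(C)c1[C@@H]3Cn1cc(-c2ccc(Br)cc2)nn1`, has bromo in the same place; compound 3 gives > 20000 nM, once more a limit. So compound 3 stands at the edge of what this assay can report, alongside the other two.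

The three steps among them, a step that the two limits leave unreadable from compound 1 to compound 2, a step that the two limits leave unreadable from compound 1 to compound 3 and a step that the two limits leave unreadable from compound 2 to compound 3, cannot be sized, because the limit of > 20000 nM in this assay, at which 3 of the 3 values shown sit, leaves every value at the same ceiling.

Compound 4, `C=C1C[C@]23C[C@@]1(O)CC[C@@H]2c1cccc(C)c1[C@@H]3Cn1cc(-c2ccccn2)nn1`, changes the group on the five-membered ring: pyridin-2-yl in place of 4-bromophenyl on an aromatic carbon. No measured step among these compounds shows any swap of this kind producing a readable number, so nothing points to a change beyond the scatter in this assay.

Compound 4 is therefore expected to sit at about 30000 nM, within a range from 10000 nM to 100000 nM. The expected step is a step that the limit leaves unreadable from compound 3 to compound 4, most likely ending again at a limit rather than a number.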

Compound 4, half-maximal inhibitory concentration: > 20000 nM
Compound 4: only a limit was reported; the forecaster's own chance of this, stated with the estimate: 80%; the middle value does not contradict the limit.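

In this assay compound 4 gives > 20000 nM, which is a limit and not a number. No step from compound 1, compound 2 or compound 3 to compound 4 can be read, because every value sits at the same ceiling: the limit of > 20000 nM in this assay, at which 4 of the 4 values shown sit.

The compounds shown leave open what true values these four have, and whether any change on the shared core would give a readable number.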